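The source may hold more compounds than are shown below. What is called first, only, known or untested is meant among the compounds shown, and "the series" means these compounds.

Measured compounds:
Compound 1 `Cc1cc(OCCCCCCC[N+]23CCN(CC2)CC3)cc(-n2cc(C(=O)Nc3cc(F)cc(F)c3)c(=O)c3ccc(N(C)C)nc32)c1` — 10.3%
Compound 2 `CN(C)c1ccc2c(=O)c(C(=O)Nc3cc(F)cc(F)c3)cn(-c3ccc(Cl)c(OCCCCCCC[N+]45CCN(CC4)CC5)c3)c2n1` — 8.08%
Compound 3 `CN(C)c1ccc2c(=O)c(C(=O)Nc3cc(F)cc(F)c3)cn(-c3ccc(OCCCCCCC[N+]4(C)CCCCC4)cc3F)c2n1` — "not active" (no number reported)

In an assay on LX2 cells for inhibition of COL1A1 promoter (Homo sapiens), read by a luciferase reporter, with a stated time of 24 h, tested at 20 uM (on this read-out lower numbers stand for a weaker effect and higher numbers for a stronger effect at the one concentration tested), compound 1 gives 10.3%. Compound 2 gives 8.08% in this assay, and the two numbers lie within the scatter of each other, so neither is told apart from the other. Compound 3 is reported in this assay as "not active" (no number reported), with no number attached. Compound 1 therefore holds the higher of the two numbers reported, but only by a gap that repeated measurement would not resolve.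

Compound 4 `Cc1cc(OCCCCCCC[N+]2(C)CCCCC2)cc(-n2cc(C(=O)Nc3cc(F)cc(F)c3)c(=O)c3ccc(N(C)C)nc32)c1` has not been measured. It differs from compound 1 in one place: a group of 7 heavy atoms (6 carbon, 1 nitrogen; one six-membered non-aromatic ring with 1 hetero atom) in place of a group of 8 heavy atoms (6 carbon, 2 nitrogen; 2 six-membered non-aromatic rings with 2 hetero atoms each), on a saturated chain carbon, seven bonds along the chain from an oxygen on an aromatic ring. Among the compounds with values here, no pair of measured compounds differs from each other in one place, so no measured step tells the size of this change. Given that the measured numbers all sit low in this assay, the step from compound 1 to compound 4 is expected to be small, a number 4.3 percentage points lower from compound 1 to compound 4 (within the scatter), downward or none beyond the scatter. Compound 4 is expected to give 6% in this assay, within -8% to 18%.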

Compound 4, a percentage reported as inhibition, at one concentration (the size of the read-out at that concentration, not a potency): 46.8%
Compound 4: middle estimate off by 40.8 percentage points, on the low side, outside the stated range (above it).
By their numbers in this assay, from the lowest: compounds 2 and 1 (each within the scatter of the next); then compound 4.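

At the place on a saturated chain carbon, seven bonds along the chain from an oxygen on an aromatic ring, the read-out in this assay turns out to be sensitive: putting the group of 7 heavy atoms in place of the group of 8 heavy atoms gives a number 36.5 percentage points higher from compound 1 to compound 4 (beyond the scatter). Within the data shown here, the step comes with net charge +1 on both groups, while the hydrogen-bond acceptors of the group go from 1 to 0, so the low numbers of the earlier compounds are not a limit for this series. Nothing available here accounts for the size of this step.

As far as these compounds go, this is a single step on a single core, so whether it carries over to other cores stays open. Also open, from the compounds shown here alone, is how a morpholine ring, a pyrrolidine ring or a shorter chain would fare at this place.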